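The compounds below may be only part of what the source reports. "The series", "measured", "known", "first", "only" and "open" are said of these compounds alone.

Measured compounds:
Compound 1, `CC(C)c1ccc(S(=O)(=O)NC(=O)Nc2ccc(Cl)cc2)s1`, 63%
Compound 2, `CC(C)(C)c1ccc(S(=O)(=O)NC(=O)Nc2ccc(Cl)cc2)s1`, 10%
Compound 3, `Cc1cc(S(=O)(=O)NC(=O)Nc2ccc(Cl)cc2)sc1C`, 73%

All three were tested in a functional assay on the whole organism (6C3HED cells, Mus musculus) for inhibition, at a dose of 300 mg/kg by the oral route; on this read-out lower numbers stand for less inhibition and higher numbers for more inhibition at the one dose given (going by the name of the read-out). Compound 1 gives 63%, compound 2 gives 10%, and compound 3 gives 73%. Compound 2 differs from compound 1 by methyl in place of hydrogen on a saturated chain carbon bound to an aromatic carbon and two saturated chain carbons, and this single change produced a number 53 percentage points lower from compound 1 to compound 2 (beyond the scatter). How the core of compound 3 differs from the core of compound 1 is not broken down here; the two values of compound 1 and compound 3 lie within the scatter of each other, so nothing can be said about their order.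

Compound 4, `CCc1sc(S(=O)(=O)NC(=O)Nc2ccc(Cl)cc2)cc1C`, has not yet been measured in this assay. It differs from compound 3 by methyl in place of hydrogen on a saturated chain carbon bound to an aromatic carbon. Within the data shown here, this is the same kind of change as the one from compound 1 to compound 2, but not the same: there the place was a saturated chain carbon bound to an aromatic carbon and two saturated chain carbons, whereas here it is a saturated chain carbon bound to an aromatic carbon only, so the earlier step is a guide rather than a template.

Because compound 1 to compound 2 showed a number 53 percentage points lower from compound 1 to compound 2 (beyond the scatter), the expectation for compound 3 to compound 4 is a step of a number 28 percentage points lower from compound 3 to compound 4 (beyond the scatter), taken as smaller than the earlier one since the surroundings of the place differ. Compound 4 is accordingly estimated at 45%, with a range from 15% to 75% expected.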

Compound 4, a percentage reported as inhibition, in the whole organism at one dose (the size of the read-out at that dose, not a potency): 58%
Compound 4: middle estimate off by 13 percentage points, on the low side, within the range that was stated.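

In this assay, methyl in place of hydrogen on a saturated chain carbon bound to an aromatic carbon gave a number 15 percentage points lower from compound 3 to compound 4 (beyond the scatter). Set beside the earlier step, this shows that the change went the same way on both cores, while the size of the step did not carry over from one core to the other: the same change on two cores in this assay, a number 53 percentage points lower (beyond the scatter) from compound 1 to compound 2 and a number 15 percentage points lower (beyond the scatter) from compound 3 to compound 4, 38 percentage points apart, beyond the scatter of two such steps It does not show what sets that size, since the two steps differ both in the core and in the place of the change, a saturated chain carbon bound to an aromatic carbon and two saturated chain carbons in the earlier step and one bound to an aromatic carbon only in the new one, and two steps alone cannot separate these differences or give a rule for a further core.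

The compounds shown leave open whether a chain longer than ethyl, such as propyl or butyl, would continue the fall seen in this assay on the core of compound 4. They also leave open how an amine or a carboxylic acid at that place would read, and whether either would stand apart from the simple saturated chains.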